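A few compounds are considered here, and "the series" means these few. Any claim that something is new, unique, unknown or untested is made for them only; others in the source may bear on it.

Compound 1, `COc1cc(OC)c(-c2coc3cc(OCc4ccccc4)ccc3c2=O)cc1OC`, is the starting point of this account. In a functional assay on B16 cells (Mus musculus) for antiproliferative activity, read by MTT assay, with a stated time of 24 h (a higher number here means a weaker inhibitor, a lower number a stronger inhibitor), compound 1 gives 2330 nM. Among the compounds with values here, only one other number stands beside it: compound 2, `COc1cc(OC)c(-c2coc3cc(OCc4ccc(Cl)cc4)ccc3c2=O)cc1OC`, which in this assay gives 2400 nM, so the two numbers sit within the scatter of each other and no order between them can be read. Within the data shown here, the single known step, a 1.0-fold higher number from compound 1 to compound 2 (0.01 log units; within the scatter), is a chloro in place of hydrogen on an aromatic carbon and left the number essentially unchanged.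

Compound 3, `COc1cc(OC)c(-c2coc3cc(OCc4cccc(Br)c4)ccc3c2=O)cc1OC`, has not been measured. It differs from compound 1 by bromo in place of hydrogen on an aromatic carbon. The step from compound 1 to compound 2 is the only one that bears on this, a halogen entering the same benzyloxy ring, and it stayed within the scatter. He therefore expects no step beyond the scatter in this assay for compound 3, an estimated 1.0-fold higher number from compound 1 to compound 3 (0.01 log units; within the scatter), and estimates compound 3 at 2400 nM, within the range 1200 nM to 4800 nM.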

Compound 3, half-maximal inhibitory concentration: 4400 nM
The estimate for compound 3 lay 1.8-fold (0.26 log units) below the measured number, and the stated range covers the measured number.
By their numbers in this assay, from the lowest: compounds 1, 2 and 3 (each within the scatter of the next).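

Compound 3 carries the (3-bromobenzyl)oxy group, and in this assay the change gives a 1.9-fold higher number from compound 1 to compound 3 (0.28 log units; within the scatter), so a bromo on this ring, meta to a large group, joins the chloro of compound 2 in leaving no readable step from the unsubstituted benzyloxy ring. The exchange of 4-chlorophenyl for 3-bromophenyl gives a 1.8-fold higher number from compound 2 to compound 3 (0.26 log units; within the scatter), so these three compounds separate neither the two halogens nor their two places on the ring, and no order among the three can be read. No measurement at hand bears on these numbers.

From the compounds shown here alone, whether an amine or a carboxylic acid on this ring would produce a step beyond the scatter remains open. So does the effect of a longer chain in place of the benzyl group.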